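This account rests on a few compounds, and the source may have more. Where it says the series, first, only, none or still open, it means among the compounds named here.

Compound 1 `COc1cc(C)cc(-c2c(-c3ccnc(-c4ccc(N(C)C)cc4)c3)cnn2CC#N)c1` and compound 2 `COc1cc(C)cc(-c2nn(CC#N)cc2-c2ccnc(-c3ccc(N(C)C)cc3)c2)c1` form a close pair, and both were tested in a functional assay on OVCAR-8 cells (Homo sapiens) for inhibition, read by sulforhodamine B assay, with a stated time of 48 h; on this read-out higher numbers stand for lower toxicity in this test and lower numbers for higher toxicity in this test. In this assay compound 1 reaches only > 100000 nM, which is a limit of the assay rather than a measured number. Compound 2 likewise gives only > 100000 nM in this assay, again a limit and not a number. Compound 1 therefore stands where every shown value stands, at the limit of > 100000 nM in this assay, at which 2 of the 2 values shown sit, and no step between measured compounds can be read from this pair. Compound 3 `COc1cc(C)cc(-c2c(-c3ccnc(-c4ccc(C(C)=O)cc4)c3)cnn2CC#N)c1` has not yet been measured in this assay. It differs from compound 1 by acetyl in place of dimethylamino on an aromatic carbon. Within the data shown here, with both known values sitting at the limit, no measured step sets a scale for this change, so the expected step is a number no higher from compound 1 to compound 3 (the limit leaves the size open), a change no larger than the usual scatter, in no particular direction. Compound 3 is thus expected to give about 100000 nM in this assay, within a range from 30000 nM to 300000 nM, and most likely it too will be reported only as a limit.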

Compound 3, concentration lethal to 50% of the cells: > 100000 nM
Compound 3: only a limit was reported (the forecaster's own chance of this, stated with the estimate: 70%); the middle value sits exactly at the limit.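

No new step can be read from compound 1 to compound 3, since the results for both compounds are limits of the assay and not numbers: the limit of > 100000 nM in this assay, at which 3 of the 3 values shown sit. The compounds shown leave open whether acetyl in place of dimethylamino on an aromatic carbon changes the read-out in this assay at all, as none of them gives a measured number there.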